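This account rests on a few compounds, and the source may have more. Where it says the series, first, only, none or still open, it means among the compounds named here.

Measured in a functional assay on A549 cells (Homo sapiens) for antiproliferative activity, read by MTT assay, with a stated time of 72 h; on this read-out higher numbers stand for weaker inhibition and lower numbers for stronger inhibition:
- compound 1 `O=C1COc2ccc(-c3cccc(NS(=O)(=O)c4ccc(F)cc4)c3)cc2N1`: 32100 nM
- compound 2 `COc1cccc(N2C(=O)COc3ccc(-c4cnc5ccccc5c4)cc32)c1`: > 40000 nM (a limit)
- compound 3 `O=C1COc2ccc(-c3cnc(Cl)c(NS(=O)(=O)c4ccc(F)cc4)c3)cc2N1c1ccc(F)cc1`: 22300 nM

Compound 2 has no numerical value on this read-out, only the limit > 40000 nM. Compound 4 `Cc1ccc(N2C(=O)COc3ccc(-c4cnc5ccccc5c4)cc32)cc1` has 4-methylphenyl in place of 3-methoxyphenyl on an amide-type nitrogen in a ring. Within the data shown here, the series holds no measured pair that differ in one place, so nothing shows the size of such a change directly. In this assay, no step beyond the scatter is expected, in either direction. The estimated step of a number no higher from compound 2 to compound 4 (the limit leaves the size open) stays within that scatter. Another reading reported only as a limit is the likeliest outcome. For compound 4 the expected value is 40000 nM, with an estimated range of 20000 nM to 80000 nM.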

Compound 4, half-maximal inhibitory concentration: > 40000 nM
Compound 4: no number, only a limit (the forecaster's own chance of this, stated with the estimate: 70%); the middle value lies on the limit itself.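

In this assay, compound 2 and compound 4 are both reported only as limits, and no step can be read between them: the limit of > 40000 nM in this assay, at which 2 of the 4 values shown sit.

The compounds shown leave open what 4-methylphenyl in place of 3-methoxyphenyl on an amide-type nitrogen in a ring does to the read-out.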